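The compounds below may be only part of what the source reports. "The series", "measured", "known", "first", "only" and "open" are said of these compounds alone.

Measured compounds:
compound 1, `CCCNCCCCOc1c(O)cc(O)c2c(=O)cc(-c3ccccc3)oc12`, "not determined" (no result reported) in a functional assay on A549 cells (Homo sapiens) for cytotoxicity, read by MTT assay, with a stated time of 48 h; a higher number here means a weaker inhibitor, a lower number a stronger inhibitor;
compound 2, `COc1c(OCCCN2CCNCC2)cc(O)c2c(=O)cc(-c3ccccc3)oc12`, 10100 nM in this assay;
compound 3, `CCCCNCCCCOc1c(O)cc(O)c2c(=O)cc(-c3ccccc3)oc12`, "not determined" (no result reported) in this assay.

Compound 3 therefore stands without a number in this assay, and compound 1 shares that position; of the three, only compound 2 carries a value, and it lies in the range where a compound is a weak inhibitor of cell growth. Within the data shown here, no pair of measured compounds differs in a single place, so no measured step exists from which the effect of a small change could be read.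

Compound 4, `CN(C)CCCCOc1c(O)cc(O)c2c(=O)cc(-c3ccccc3)oc12`, is reached from compound 3 by one change: dimethylamino in place of butylamino on a saturated chain carbon, four bonds along the chain from an oxygen on an aromatic ring. The amine at the end of the chain changes, while the shared core and the chain itself stay as they are. Among the measured compounds shown here, since no measured step is available and compound 3 itself has no number, the expectation for compound 4 rests only on the value of compound 2 in this assay. In this assay the change from compound 3 to compound 4 is expected to move the number by no more than the usual scatter, in no particular direction. For compound 4 the value in this assay is estimated at 10000 nM, with a range from 3000 nM to 40000 nM.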

Compound 4, half-maximal inhibitory concentration: > 100000 nM
Compound 4 was reported as a limit (the forecaster's own chance of this, stated with the estimate: 25%); middle value at least 10-fold (1.00 log units) from the limit.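

Among these compounds, compound 3 has no number in this assay, so no step to compound 4 can be read. Compound 4 is reported with > 100000 nM, which is a limit and not a number. The compounds shown leave open how far, and in which direction, replacing butylamino with dimethylamino moves the value.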